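Vinyl for Chloromethyl on a Carbonyl, Tested a Second Time

The source may hold more compounds than are shown below. What is called first, only, known or untested is meant among the compounds shown, and "the series" means these compounds.

Compound 2 `CCOC(=O)c1cc(-c2ccc(Oc3ccccc3)cc2)nn1C1CCCN(C(=O)CCl)C1` and compound 1 `C=CC(=O)N1CCCC(n2nc(-c3ccc(Oc4ccccc4)cc3)cc2C(=O)OCC)C1` share one core and differ in a single place. In a functional assay on Maver1 cells (Homo sapiens) for inhibition, read by luminescence and CellTiter-Glo, with a stated time of 72 h (a higher number here means a weaker inhibitor, a lower number a stronger inhibitor), compound 2 gives 1200 nM. Compound 1 is reported in this assay as a limit, > 60000 nM, and not as a number. The step of an at least 50-fold higher number from compound 2 to compound 1 (1.69 log units; beyond the scatter) is thus a lower bound, resting on (the limit of > 60000 nM in this assay, at which 1 of the 3 values shown sits). The change behind it is vinyl in place of chloromethyl on a carbonyl carbon.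

Compound 3 `O=C(CCl)Nc1cccc(Cn2nc(-c3ccc(Oc4ccccc4)cc3)cc2C(=O)O)c1` carries a different core; how its core and that of compound 2 differ is not broken down here. In this assay compound 3 gives 4700 nM, a higher number than compound 2 gives.

Compound 4 `C=CC(=O)Nc1cccc(Cn2nc(-c3ccc(Oc4ccccc4)cc3)cc2C(=O)O)c1` has not yet been measured in this assay. It differs from compound 3 by vinyl in place of chloromethyl on a carbonyl carbon. Within the data shown here, this is the same kind of change as the one from compound 2 to compound 1, though not the same: in compound 3 the carbonyl carbon's other neighbour is an amide-type nitrogen, whereas in compound 2 it is an amide-type nitrogen in a ring. Compound 3 already sits at 4700 nM. Should the earlier pattern hold, compound 4 is expected to show a step of a 19-fold higher number from compound 3 to compound 4 (1.28 log units; beyond the scatter), to be set beside an at least 50-fold higher number from compound 2 to compound 1 (1.69 log units; beyond the scatter). The estimate for compound 4 is 90000 nM, between 15000 nM and 400000 nM, and a limit rather than a number is thought the likelier report.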

Compound 4, half-maximal inhibitory concentration: 37400 nM
For compound 4 the middle estimate is 2.4-fold (0.38 log units) above the measured one; low and high end bracket the measured number.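

In this assay, vinyl in place of chloromethyl on a carbonyl carbon raises the number on both cores, and on the second core the result is an 8.0-fold higher number from compound 3 to compound 4 (0.90 log units; beyond the scatter), so in these two pairs the direction of the change carries over. The size of the step does not carry over unchanged, and the two steps stand apart: the same change on two cores in this assay, an at least 50-fold higher number (1.69 log units; beyond the scatter) from compound 2 to compound 1 and an 8.0-fold higher number (0.90 log units; beyond the scatter) from compound 3 to compound 4, at least 6.2-fold (0.79 log units) apart, beyond the scatter of two such steps Compound 1 is reported as a limit and not as a number, so the earlier step is only a lower bound and the true gap between the two steps remains unknown, and the two pairs do not show which of the differences between their cores goes with that gap: the limit of > 60000 nM in this assay, at which 1 of the 4 values shown sits.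

The compounds shown leave open how a bromomethyl or an ethynyl group on the same carbonyl carbon would read in this assay, as they hold only chloromethyl and vinyl at that place. They also leave open whether the ethyl ester or the carboxylic acid has any bearing on the size of the step, and whether the rise would recur on a third core.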